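The source may hold more compounds than are shown below. What is called first, only, known or untested is meant among the compounds shown, and "the series" means these compounds.

Working notes on the series. In a functional assay on MCF7 cells (Homo sapiens) for cytotoxicity, read by MTT assay, with a stated time of 72 h (on this read-out higher numbers stand for weaker inhibition and lower numbers for stronger inhibition), compound 1 (`N#Cc1ccc(/C=C/C(=O)Nc2cc3c(Nc4ccc(F)c(Cl)c4)ncnc3cc2O[C@H]2CCOC2)cc1`) gives 9830 nM, the lowest of the two numbers available. Compound 3 (`COc1cc(/C=C/C(=O)Nc2cc3c(Nc4ccc(F)c(Cl)c4)ncnc3cc2OC)cc(OC)c1`) gives 38500 nM, a higher number than that of compound 1 and beyond the scatter. Compound 2 (`COc1cc2ncnc(Nc3ccc(F)c(Cl)c3)c2cc1NC(=O)/C=C/c1ccc(C#N)cc1`) is reported as "not active" (no number reported), without a number, so not every member of the series yields a value.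

Compound 4 (`O=C(/C=C/c1ccc(F)cc1Cl)Nc1cc2c(Nc3ccc(F)c(Cl)c3)ncnc2cc1O[C@H]1CCOC1`) is the next to be read. It carries 2-chloro-4-fluorophenyl in place of 4-cyanophenyl on a double-bonded chain carbon bound to a double-bonded chain carbon.

Within the data shown here, no two measured compounds differ in one place only, so the data offer no direct precedent for this exchange. The expectation therefore stays anchored on compound 1 at 9830 nM. In this assay, the step of a 1.0-fold lower number from compound 1 to compound 4 (0.01 log units; within the scatter) is expected to stay within the scatter, with no direction favoured. For compound 4 the estimated value is 9500 nM, with an expected range of 3000 nM to 30000 nM.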

Compound 4, half-maximal inhibitory concentration: 26200 nM
The estimate for compound 4 lay 2.8-fold (0.44 log units) below the measured number, within the range that was stated.
By their numbers in this assay, from the lowest: compound 1; then compounds 4 and 3 (each within the scatter of the next).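

Among these compounds, replacing 4-cyanophenyl with 2-chloro-4-fluorophenyl on a double-bonded chain carbon bound to a double-bonded chain carbon gives the first comparison that differs in one place only. In this assay the change reads as a 2.7-fold higher number from compound 1 to compound 4 (0.43 log units; beyond the scatter) and shows that the number responds to the aryl group at this position, though the step is modest. Nothing measured here accounts for the shift, so it remains an observation on this single pair.

The compounds shown leave open whether the step follows the loss of the nitrile, the entry of the chlorine or the entry of the fluorine, as the two halogens enter together. Going by these compounds, how a phenyl ring carrying an amine or a carboxylic acid would read at this position also remains open.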